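Swapping the Group on Sulfur in Compound 1

The source may hold more compounds than are shown below. What is called first, only, known or untested is meant among the compounds shown, and "the series" means these compounds.

In a functional assay on HeLa cells (Homo sapiens) for inhibition, read by CCK-8 assay, with a stated time of 72 h, tested at 2 uM (on this read-out lower numbers stand for less inhibition of growth and higher numbers for more inhibition of growth at the one concentration tested), compound 1 `CCc1ccc(SCc2ccc(/C=C/C(=O)Nc3ccccc3N)cc2)cc1` gives 3.96% as the lowest of three numbers. Compound 2 `Nc1ccccc1NC(=O)c1ccc(CSc2cccc(F)c2)cc1` stands at 22.5% and compound 3 `Cc1ccc(SCc2ccc(C(=O)Nc3ccccc3N)cc2)cc1` at 33.8% on this measure. Compound 4 `Nc1ccccc1NC(=O)/C=C/c1ccc(CSc2cccc3ccccc23)cc1` has not been measured yet and carries naphthalen-1-yl in place of 4-ethylphenyl on a sulfur. The closest measured swap on a sulfur is a number 11.3 percentage points higher from compound 2 to compound 3 (beyond the scatter) and it sits on a different core, so it is only a rough guide. A step of similar modest size is expected, upward since compound 1 at 3.96% has little room to fall. The expected step is a number 11 percentage points higher from compound 1 to compound 4 (beyond the scatter) as an estimate only. Compound 4 is estimated at 15% (expected range 2% to 36%).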

Compound 4, percent growth inhibition at one concentration: 20.6%
Compound 4: the middle estimate sits 5.6 percentage points below what was measured; the range from low to high includes it.
By their numbers in this assay, from the lowest: compound 1; then compounds 4 and 2 (each within the scatter of the next); then compound 3.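

In this assay the core of compound 1 also responds to a swap on the sulfur, with a number 16.6 percentage points higher from compound 1 to compound 4 (beyond the scatter) when naphthalen-1-yl replaces 4-ethylphenyl. The earlier swap on a sulfur sat on a different core, and here the group entering has 2 six-membered aromatic rings where the group leaving has one. Nothing available explains why the number changed.

On these data alone, whether an amine or a carboxylic acid on the entering ring would move the number further stays open. So does whether naphthalen-1-yl would give a similar step on the core of compound 2.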